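Side-chain change from compound 2 to compound 3

The source may hold more compounds than are shown below. What is called first, only, known or untested is meant among the compounds shown, and "the series" means these compounds.

- Compound 1 `CC(C)c1n[nH]c2c(NCc3ccc(-c4ccccn4)cc3)nc(NCC(C)(C)O)nc12` gives 24 nM in a functional assay on MCF7 cells (Homo sapiens) for cytotoxicity, read by fluorescence, with a stated time of 72 h; a lower number here means a stronger inhibitor, a higher number a weaker inhibitor
- Compound 2 `CC(C)c1n[nH]c2c(NCc3ccc(-c4ccccn4)cc3)nc(NCC(N)CO)nc12` gives 310 nM in this assay

Compound 2 stands highest of the two numbers. Compound 3 `COc1ccc(CNc2nc(NCc3ccc(-c4ccccn4)cc3)c3[nH]nc(C(C)C)c3n2)cc1` differs from compound 2 in one place: 4-methoxyphenyl in place of 1-amino-2-hydroxyethyl on a saturated chain carbon bound to a nitrogen on an aromatic ring. For the measured compounds named here, the sole measured step, a 13-fold higher number from compound 1 to compound 2 (1.11 log units; beyond the scatter), is large, lies beyond the scatter and sits at this same place. Going by the values given here, no measured compound carries a ring there, so the estimate stays loose. With compound 1 at 24 nM as the only lower reference, a moderate move towards lower numbers in this assay is expected, an estimated 3.4-fold lower number from compound 2 to compound 3 (0.54 log units; beyond the scatter). Compound 3 is expected at 90 nM, with a range of 20 nM to 400 nM.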

Compound 3, half-maximal inhibitory concentration: 5300 nM
For compound 3 the middle estimate is 59-fold (1.77 log units) below the measured one, outside the stated range (above it).
By their numbers in this assay, from the lowest: compound 1; then compound 2; then compound 3.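

In this assay, for the compounds shown here, a ring at this position, on a saturated chain carbon bound to a nitrogen on an aromatic ring, is now seen for the first time, and it raises the number further (a 17-fold higher number from compound 2 to compound 3 (1.23 log units; beyond the scatter)). Against the tertiary alcohol the step is larger still (a 220-fold higher number from compound 1 to compound 3 (2.34 log units; beyond the scatter)), which leaves compound 3 the weakest of the three and both ring-free chains ahead of 4-methoxyphenyl. No evidence on the cause of this loss is available.

As far as these compounds go, whether the loss follows the ring or its methoxy group stays open; an unsubstituted phenyl or a pyridine ring here would separate the two. Also open, from the compounds shown here alone, is whether a longer chain ending in a hydroxyl keeps the level of compound 1.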